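Ethoxy to Propoxy: An Expected Small Step

The source may report more compounds than this note shows. Statements on the series, on what has been measured and on what is new or still open speak of the compounds shown alone.

Compound 1 `O=C1CSC(c2ccccc2)CN1` is the plainest member of this set. In an assay on isolated protein for inhibition of Amine oxidase [flavin-containing] B (Homo sapiens), read by spectrophotometry (on this read-out higher numbers stand for weaker inhibition and lower numbers for stronger inhibition), compound 1 gives only a limit, > 100000 nM, not a number. Compound 2 `CCCOc1ccc(C2CNC(=O)CS2)cc1` carries a propoxy group on the aromatic ring and in this assay gives 2400 nM. The change is an at least 41-fold lower number from compound 1 to compound 2 (1.61 log units; beyond the scatter); the starting point is the limit (the limit of > 100000 nM in this assay, at which 1 of the 3 values shown sits). Compound 3 `CCOc1ccc(C2CNCCS2)cc1` has an ethoxy group and lacks the carbonyl of the shared core; in this assay compound 3 gives 2100 nM. For the measured compounds named here, compound 3 therefore stands alongside compound 2, the two within the scatter of each other, and the only other value shown is a limit. Compound 4 `CCCOc1ccc(C2CNCCS2)cc1` differs from compound 3 by methyl in place of hydrogen on a saturated chain carbon, two bonds along the chain from an oxygen on an aromatic ring. Going by the values given here, no measured step isolates this change: the step from compound 1 to compound 2 concerns adding a whole propoxy group, and compound 2 and compound 3 differ in two places. With compound 2 and compound 3 so close, the expected step is a 1.2-fold lower number from compound 3 to compound 4 (0.07 log units; within the scatter), nothing beyond the scatter. Compound 4 is thus estimated at 1800 nM, between 700 nM and 4500 nM.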

Compound 4, inhibition constant: 130 nM
The estimate for compound 4 lay 14-fold (1.14 log units) above the measured number; measured number below the stated range.
By their numbers in this assay, from the lowest: compound 4; then compounds 3 and 2 (each within the scatter of the next). At a limit, above all of these: compound 1.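

In this assay, this single change at the end of the ethoxy chain turns out to be large: a 16-fold lower number from compound 3 to compound 4 (1.21 log units; beyond the scatter). A methyl in place of hydrogen on a saturated chain carbon, two bonds along the chain from an oxygen on an aromatic ring, can therefore matter a great deal with this core, something that compound 2 and compound 3, which differ in two places, could not isolate. Nothing measured here explains why this one added carbon has such an effect.

From the compounds shown here alone, whether a longer chain such as butoxy would lower the number further, or whether propoxy is already the best length, remains open. So does the effect of an amine or a carboxylic acid at the end of the chain.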